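Working notes: shortening the chain of compound 2

This account rests on a few compounds, and the source may have more. Where it says the series, first, only, none or still open, it means among the compounds named here.

- compound 1 `CCN(C(=O)c1cc(C(C)C)c(O)cc1O)c1ccc(NC(=O)CCCCCCC(=O)NO)cc1` gives 3560 nM
- compound 2 `CC(C)c1cc(C(=O)N(C)c2ccc(NC(=O)CCCCCCCCC(=O)NO)cc2)c(O)cc1O` gives 590 nM

Both values come from a functional assay on HCT-116 cells (Homo sapiens) for inhibition, read by sulforhodamine B assay, with a stated time of 48 h (on this read-out higher numbers stand for weaker inhibition of growth and lower numbers for stronger inhibition of growth), and compound 2 holds the lower number of the pair. In the same read-out compound 2 gives 590 nM and compound 1 gives 3560 nM. The gap between these two values lies beyond the scatter. Among the compounds with values here, no measured pair differs in one place only, so the series offers no direct step for calibration.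

The next compound to be measured is compound 3 `CC(C)c1cc(C(=O)N(C)c2ccc(NC(=O)CCCCCCCC(=O)NO)cc2)c(O)cc1O`. The change from compound 2 is hydroxycarbamoyl in place of (hydroxycarbamoyl)methyl on a saturated chain carbon, seven bonds along the chain from a carbonyl carbon and it puts hydroxycarbamoyl in place of (hydroxycarbamoyl)methyl on a saturated chain carbon, seven bonds along the chain from a carbonyl carbon.

In this assay a modest step towards a higher number is expected, possibly not beyond the scatter. Within the data shown here, the only higher reference is compound 1 at 3560 nM and that compound differs in more than this one place. The expected change is a 1.5-fold higher number from compound 2 to compound 3 (0.18 log units; within the scatter) as a working assumption. Compound 3 is estimated at 900 nM with an expected range of 300 nM to 2500 nM for now.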

Compound 3, concentration for 50% growth inhibition: 1060 nM
Compound 3: middle estimate off by 1.2-fold (0.07 log units), on the low side, and the stated range covers the measured number.
By their numbers in this assay, from the lowest: compounds 2 and 3 (each within the scatter of the next); then compound 1.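

In this assay the series now has its first step at a single place: hydroxycarbamoyl in place of (hydroxycarbamoyl)methyl on a saturated chain carbon, seven bonds along the chain from a carbonyl carbon, gives a 1.8-fold higher number from compound 2 to compound 3 (0.25 log units; within the scatter), so the read-out does not separate these two chain lengths. The earlier pair could not show this, since compound 1 and compound 2 differ in more than one place, and compound 1 and compound 3 also differ in more than one place, so the size of the gap to compound 1 still cannot be assigned to chain length or to any other single change. Nothing available here gives a reason for the step or bears on how it arises.

Open, as far as these compounds go, is whether the flat reading holds further along this chain, for example with a longer chain ending in hydroxycarbamoyl or with a shorter one than in compound 3. Also open, from the compounds shown here alone, is how the read-out responds when a carboxylic acid stands in place of the hydroxycarbamoyl end group on the chain of compound 2.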